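Exchanging one aryl group among compounds sitting at the limit

The source may hold more compounds than are shown below. What is called first, only, known or untested is meant among the compounds shown, and "the series" means these compounds.

In a functional assay on HepG2 cells (Homo sapiens) for inhibition, read by MTT assay, with a stated time of 72 h (on this read-out higher numbers stand for weaker inhibition and lower numbers for stronger inhibition), three compounds have been measured, and every value is a limit of the assay rather than a number.
Compound 1 `CC(C)n1ncc2c(C(=O)Nc3cccnc3)cccc21` gives > 40000 nM.
Compound 2 `CC(C)n1ncc2c(C(=O)NC3CCCC3)cccc21` gives > 40000 nM.
Compound 3 `Cc1ccc(-n2cc(CNC(=O)c3cccc4c3cnn4C(C)C)nn2)cc1C` gives > 40000 nM.

Compound 3 therefore stands at the limit of > 40000 nM in this assay, at which 3 of the 3 values shown sit, where all three values sit. Compound 4 `CC(C)n1ncc2c(C(=O)NCc3cn(-c4ccc(I)cc4)nn3)cccc21` differs from compound 3 by a single exchange: 4-iodophenyl in place of 3,4-dimethylphenyl on an aromatic nitrogen. Among the compounds with values here, the only measured step between single-point neighbours, a step that the two limits leave unreadable from compound 1 to compound 2, cannot be sized, since both ends are limits. Within the data shown here, no measured step speaks to the exchange of an aryl group, so nothing beyond the scatter can be expected in either direction. Compound 4 is estimated to stay at the limit as well, with an estimate of 60000 nM, ranging from 20000 nM to 200000 nM, an expected step that the limit leaves unreadable from compound 3 to compound 4.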

Compound 4, half-maximal inhibitory concentration: > 40000 nM
Compound 4 was reported as a limit; the forecaster's own chance of this, stated with the estimate: 85%; the middle value is on the limit's open side.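

Compound 3 and compound 4 both sit at the assay's limit, so no step between them can be read: the limit of > 40000 nM in this assay, at which 4 of the 4 values shown sit.

The compounds shown leave open which change to the shared structure, if any, would give a true measured number in this assay.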